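This account rests on a few compounds, and the source may have more. Where it says the series, first, only, none or still open, it means among the compounds named here.

Of the compounds shown here, three have been tested in a functional assay on NCI-H460 cells (Homo sapiens) for cytotoxicity, read by MTT assay; a lower number here means a stronger inhibitor, a higher number a weaker inhibitor. Compound 1 `Cc1nc(Nc2ccc(Cl)cc2)sc1C(=O)/C=C/c1ccccc1` carries a 4-chlorophenyl group on a nitrogen on an aromatic ring. For compound 1 the result is a limit of the assay, > 25000 nM. Compound 3 `Cc1nc(Nc2cccc(Cl)c2)sc1C(=O)/C=C/c1ccccc1` differs from compound 1 only by 3-chlorophenyl in place of 4-chlorophenyl on a nitrogen on an aromatic ring. For compound 3 the result is again a limit of the assay, > 25000 nM. The step that the two limits leave unreadable from compound 1 to compound 3 therefore cannot be read, because both results sit at the limit of > 25000 nM in this assay, at which 2 of the 3 values shown sit. Compound 2 `COc1cc(/C=C/C(=O)c2sc(Nc3ccc(Cl)cc3)nc2C)cc(OC)c1OC` has a different core, and the difference between the two cores is not broken down here. In this assay, within the data shown here, compound 2 gives 22000 nM, the only actual number among the three results. Compound 4 `COc1cc(/C=C/C(=O)c2sc(Nc3cccc(Cl)c3)nc2C)cc(OC)c1OC`, not yet measured, differs from compound 2 by 3-chlorophenyl in place of 4-chlorophenyl on a nitrogen on an aromatic ring, the same change as from compound 1 to compound 3. Because the step that the two limits leave unreadable from compound 1 to compound 3 gave no readable size, compound 4 is expected to stay close to compound 2, an estimated step of a 1.1-fold higher number from compound 2 to compound 4 (0.06 log units; within the scatter). The estimate for compound 4 is 25000 nM, with a range from 12000 nM to 60000 nM, and a result that is only a limit would not be surprising.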

Compound 4, half-maximal inhibitory concentration: > 25000 nM
Compound 4 ended at the assay's limit; the forecaster's own chance of this, stated with the estimate: 50%; the middle value lies on the limit itself.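

In this assay compound 4 gives > 25000 nM, which is a limit of the assay and not a number. Replacing 4-chlorophenyl with 3-chlorophenyl on this core gives an at least 1.1-fold higher number from compound 2 to compound 4 (0.05 log units; that floor lies within the scatter), so the data show no change beyond the usual scatter, but they do not rule out a larger one. The same change from compound 1 to compound 3 cannot be read, and whether it acts alike on the two cores stays unknown because the results pile up at one value: the limit of > 25000 nM in this assay, at which 3 of the 4 values shown sit.

The compounds shown leave open how the result would respond to a different group in place of the chlorine on the phenyl ring, such as an amine or a carboxylic acid. They also leave open whether any such group on either core would give a number well clear of the limit in this assay, where a real comparison between the cores could be made.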